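Aryl swap on the urea nitrogen of a shared core

The source may hold more compounds than are shown below. What is called first, only, known or untested is meant among the compounds shown, and "the series" means these compounds.

Measured compounds:
Compound 1, `CCOc1ccc(NC(=O)Nc2cccc(CNc3nccnc3Cl)c2)cc1`, gives 9080 nM in a functional assay on T-24 cells (Homo sapiens) for antiproliferative activity, read by MTT assay, with a stated time of 48 h; on this read-out higher numbers stand for weaker inhibition and lower numbers for stronger inhibition.
Compound 2, `Cc1ccc(NC(=O)Nc2cccc(CNc3nccnc3Cl)c2)cc1Cl`, gives 7390 nM in this assay.
Compound 3, `O=C(Nc1cccc(CNc2nccnc2Cl)c1)Nc1ccc(Cl)cc1Br`, gives 6650 nM in this assay.

Compound 3 has the lowest of the three numbers, yet every gap to it is within the scatter: a 1.1-fold lower number from compound 2 to compound 3 (0.05 log units; within the scatter) and a 1.4-fold lower number from compound 1 to compound 3 (0.14 log units; within the scatter). The third pair, a 1.2-fold lower number from compound 1 to compound 2 (0.09 log units; within the scatter), is likewise within the scatter. All three differ only in the aryl group on the amide-type nitrogen, and no change there has moved the number beyond the scatter.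

Compound 4, `Cc1ccccc1NC(=O)Nc1cccc(CNc2nccnc2Cl)c1`, carries the same kind of change: 2-methylphenyl in place of 2-bromo-4-chlorophenyl on an amide-type nitrogen. Within the data shown here, the steps that bear on it are those from compound 1 and compound 2 to compound 3, both small, so no step beyond the scatter is expected in this assay. The step from compound 3 to compound 4 is estimated as a 1.1-fold higher number from compound 3 to compound 4 (0.05 log units; within the scatter), and compound 4 is expected to give about 7500 nM, within 3500 nM to 16000 nM.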

Compound 4, half-maximal inhibitory concentration: 13600 nM
Estimate against measurement, compound 4: 1.8-fold (0.26 log units) below; measured number inside the range.
By their numbers in this assay, from the lowest: compounds 3, 2, 1 and 4 (each within the scatter of the next, the first and the last beyond it).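

In this assay, this position now gives its first step beyond the scatter (a 2.0-fold higher number from compound 3 to compound 4 (0.31 log units; beyond the scatter)), modest in size, with 2-methylphenyl in place of 2-bromo-4-chlorophenyl on the amide-type nitrogen. The other two new steps stay within the scatter (a 1.8-fold higher number from compound 2 to compound 4 (0.26 log units; within the scatter); a 1.5-fold higher number from compound 1 to compound 4 (0.18 log units; within the scatter)), so among these aryl groups only the two ends of the order are separated. No measurement given here accounts for the step.

The compounds shown carry only chlorine, bromine, methyl and ethoxy on this aryl ring, which leaves open how an amine or a carboxylic acid there would read. The change from compound 3 to compound 4 also swaps bromine, chlorine and methyl together, and these compounds do not separate their contributions.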